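Swapping One Small Ring for Another on a Weak Inhibitor

A few compounds are considered here, and "the series" means these few. Any claim that something is new, unique, unknown or untested is made for them only; others in the source may bear on it.

Two compounds share a large core and differ in the group attached to it. Compound 1 `COc1cc2c(Oc3ccc(NC(=O)c4c(C)n(C)n(-c5ccccc5)c4=O)cc3F)ccnc2cc1OCCCN1CCN(C)CC1` and compound 2 `COc1cc2c(Oc3ccc(NS(=O)(=O)c4cccc(-c5cnn(C)c5)c4)cc3F)ccnc2cc1OCCCN1CCN(C)CC1` were both tested in a functional assay on HCC827 cells (Homo sapiens) for cytotoxicity, read by MTT assay, with a stated time of 48 h; a higher number here means a weaker inhibitor, a lower number a stronger inhibitor. Compound 1 gives 2580 nM, and compound 2 gives 2830 nM. The two numbers lie within the usual scatter of each other, so compound 2 cannot be told apart from compound 1; both are weak inhibitors on this scale.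

Compound 3 `COc1cc2c(Oc3ccc(NS(=O)(=O)c4cccc(-c5ccco5)c4)cc3F)ccnc2cc1OCCCN1CCN(C)CC1` has not yet been measured. It differs from compound 2 in one place: furan-2-yl in place of 1-methyl-1H-pyrazol-4-yl on an aromatic carbon. Within the data shown here, no measured pair shows the effect of such a swap, so there is no direct guide. Because compound 2 gives 2830 nM and the change is small, the step of a 1.1-fold higher number from compound 2 to compound 3 (0.03 log units; within the scatter) is expected to stay within the scatter. Compound 3 is therefore estimated at 3000 nM in this assay, with a likely range from 1200 nM to 8000 nM.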

Compound 3, half-maximal inhibitory concentration: 3110 nM
The estimate for compound 3 lay 1.0-fold (0.02 log units) below the measured number; low and high end bracket the measured number.
By their numbers in this assay, from the lowest: compounds 1, 2 and 3 (each within the scatter of the next).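

In this assay, replacing 1-methyl-1H-pyrazol-4-yl with furan-2-yl gives a 1.1-fold higher number from compound 2 to compound 3 (0.04 log units; within the scatter). On this aromatic carbon, meta to a large group, these two five-membered aromatic rings therefore cannot be told apart, even though one has 2 hetero atoms, both nitrogen, and the other has 1, an oxygen. Nothing measured here explains why the two rings read alike.

These two rings alone cannot show whether this position responds to any change at all, so a carboxylic acid or a dimethylamino group in place of the ring would be a sharper test. From the compounds shown here alone, it also remains open whether a plain phenyl or a longer chain at the same carbon would give a number that stands clear of the scatter.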